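Trading an iodophenyl amine for a pyrrolidine ring

The compounds below may be only part of what the source reports. "The series", "measured", "known", "first", "only" and "open" are said of these compounds alone.

In a functional assay on HeLa cells (Homo sapiens) for inhibition, read by sulforhodamine B assay (on this read-out higher numbers stand for weaker inhibition and lower numbers for stronger inhibition), compound 1 `O=C1C=C(Nc2ccccc2F)C(=O)c2c1nc1n2[C@H]2OC[C@@H](O)[C@H]2OC1` with 2-fluorophenyl on an amine nitrogen gives 5120 nM as its value. Compound 3 `O=C1C=C(Nc2ccc(I)cc2)C(=O)c2c1nc1n2[C@H]2OC[C@@H](O)[C@H]2OC1` with 4-iodophenyl on that nitrogen gives 4070 nM as its value. The gap of a 1.3-fold lower number from compound 1 to compound 3 (0.10 log units; within the scatter) is within the scatter, so compound 3 stands level with compound 1 at the low end of these numbers. Compound 2 `O=C1C=C(NC2CCCC2)C(=O)c2c1nc1n2[C@H]2OC[C@@H](O)[C@H]2OC1` with cyclopentyl on that nitrogen gives > 16000 nM as its reading, which is a limit of the assay and not a number.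

The next structure is compound 4 `O=C1C=C(N2CCCC2)C(=O)c2c1nc1n2[C@H]2OC[C@@H](O)[C@H]2OC1` with pyrrolidin-1-yl in place of (4-iodophenyl)amino on a double-bonded ring carbon. The closest guide is compound 2, which also carries a non-aromatic ring instead of an aromatic one. Its steps are an at least 3.1-fold higher number from compound 1 to compound 2 (0.49 log units; beyond the scatter) and an at least 3.9-fold lower number from compound 2 to compound 3 (0.59 log units; beyond the scatter) and both lie beyond the scatter. Among the measured compounds shown here, compound 4 also has no hydrogen-bond donor in this group, and no tested compound shows what that alone does. A higher number is therefore expected, with an estimated 3.2-fold higher number from compound 3 to compound 4 (0.50 log units; beyond the scatter) as its size. In this assay the estimate for compound 4 is 13000 nM (range 6000 nM to 25000 nM) and the assay may report only a limit.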

Compound 4, half-maximal inhibitory concentration: > 16000 nM
Compound 4 was reported as a limit; the forecaster's own chance of this, stated with the estimate: 45%; at least 1.2-fold (0.09 log units) between middle value and limit.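

In this assay, pyrrolidin-1-yl on the double-bonded ring carbon gives an at least 3.9-fold higher number from compound 3 to compound 4 (0.59 log units; beyond the scatter) and an at least 3.1-fold higher number from compound 1 to compound 4 (0.49 log units; beyond the scatter), so a second non-aromatic ring, this one with no hydrogen-bond donor, also reads as weaker inhibition than both aromatic amines. The reading for compound 4 is a limit of the assay and not a number, yet it shows that at this position the weak side of the series holds a non-aromatic ring both with the amine hydrogen, in compound 2, and without it, in compound 4. The step from compound 2 to compound 4 cannot be read, and any effect of the amine hydrogen on these two rings stays hidden, because both readings are limits: the limit of > 16000 nM in this assay, at which 2 of the 4 values shown sit.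

As far as these compounds go, what stays open is which loss matters, since the aromatic ring and the amine hydrogen leave together in compound 4. A methyl group on the nitrogen of (4-iodophenyl)amino would keep the aromatic ring without that hydrogen, while a benzylamine would place a carbon between the nitrogen and the aromatic ring.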